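The source may report more compounds than this note shows. Statements on the series, on what has been measured and on what is new or still open speak of the compounds shown alone.

Measured in a functional assay on OVCAR-3 cells (Homo sapiens) for inhibition, read by sulforhodamine B assay, with a stated time of 48 h; on this read-out lower numbers stand for stronger inhibition of growth and higher numbers for weaker inhibition of growth:
- compound 1 `CCOC(=O)c1nn(-c2ccc(Cl)cc2)c(-c2ccc(F)cc2)c1CNC(C)(C)C`: 159000 nM; > 537000 nM (2 entries)
- compound 2 `Cc1ccc(-c2c(CNC(C)(C)C)c(C(=O)O)nn2-c2ccccc2)cc1`: 283000 nM
- compound 3 `CC(C)(C)NCc1c(C(=O)O)nn(-c2ccc(Cl)cc2)c1-c1ccc(F)cc1`: 116000 nM

One of the two entries for compound 1 is a limit of the assay and not a number.

In this assay, compound 3 at 116000 nM holds the lower of the two single numbers, and compound 2 at 283000 nM lies higher, a gap beyond the usual scatter. Compound 4 `CC(C)(C)NCc1c(C(=O)O)nn(-c2ccc(Cl)cc2)c1-c1ccccc1` is the next to be tested, and it differs from compound 3 at one place: hydrogen in place of fluoro on an aromatic carbon. This is hydrogen in place of fluoro on an aromatic carbon, para to a large group. Among the compounds with values here, no measured pair shows this change, so the expectation is cautious. The expected step of a 1.1-fold higher number from compound 3 to compound 4 (0.05 log units; within the scatter) stays within the scatter, with no clear direction. For compound 4 the estimated value is 130000 nM, with an expected range from 60000 nM to 290000 nM.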

Compound 4, concentration for 50% growth inhibition: 653000 nM
Compound 4: middle estimate off by 5.0-fold (0.70 log units), on the low side; the measured number lies above the stated range.
By their numbers in this assay, from the lowest: compound 3; then compound 2; then compound 4.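

In this assay, within the data shown here, the change from 4-fluorophenyl to phenyl, on an aromatic carbon para to a large group, can now be read for the first time, with a 5.6-fold higher number from compound 3 to compound 4 (0.75 log units; beyond the scatter). At this place, then, hydrogen does not stand in for fluoro without a loss of growth inhibition, although this rests on a single pair. Nothing measured here accounts for the size of this step. As far as these compounds go, whether chloro, methoxy or an amine at this place would match fluoro remains open. So does whether the same step would appear with the ethyl ester of compound 1 in place of the carboxylic acid.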